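The compounds below may be only part of what the source reports. "The series", "measured", "known", "first", "only" and "open" are said of these compounds alone.

Compound 1, `C/C=C\C(=O)Nc1cc(Nc2nccc(-c3cn(C)c4ccccc34)n2)c(OC)cc1N(C)CCN(C)C`, gives 6930 nM in a functional assay on HepG2 cells (Homo sapiens) for antiproliferative activity, read by MTT assay, with a stated time of 72 h; on this read-out lower numbers stand for stronger inhibition and higher numbers for weaker inhibition.
Compound 2, `CC/C=C\C(=O)Nc1cc(Nc2nccc(-c3cn(C)c4ccccc34)n2)c(OC)cc1N(C)CCN(C)C`, gives 6670 nM.
Compound 3, `CC/C=C\C(=O)Nc1cc(Nc2nc(C)cc(-c3cn(C)c4ccccc34)n2)c(OC)cc1N(C)CCN(C)C`, gives 2050 nM.

Compound 4, `COc1cc(N(C)CCN(C)C)c(NC(=O)/C=C\C(C)C)cc1Nc1nc(C)cc(-c2cn(C)c3ccccc23)n1`, is not yet measured. It differs from compound 3 by methyl in place of hydrogen on a saturated chain carbon bound to a double-bonded chain carbon and a saturated chain carbon. The same kind of change has already been tried once: compound 2 differs from compound 1 by methyl in place of hydrogen on a saturated chain carbon bound to a double-bonded chain carbon, and in this assay this gave a 1.0-fold lower number from compound 1 to compound 2 (0.02 log units; within the scatter). The place is not identical, though: in the earlier pair the saturated chain carbon is bound to a double-bonded chain carbon only, while in the new pair it is bound to a double-bonded chain carbon and a saturated chain carbon. The cores of compound 1 and compound 3 differ too, but that difference is not broken down here. Because the earlier step of a 1.0-fold lower number from compound 1 to compound 2 (0.02 log units; within the scatter) lay within the scatter, little movement is expected for compound 4, a 1.0-fold higher number from compound 3 to compound 4 (0.01 log units; within the scatter). The estimate for compound 4 is 2100 nM, expected between 900 nM and 5000 nM.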

Compound 4, half-maximal inhibitory concentration: 3550 nM
The estimate for compound 4 lay 1.7-fold (0.23 log units) below the measured number; low and high end bracket the measured number.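

In this assay, the added methyl on the saturated chain carbon gave a 1.7-fold higher number from compound 3 to compound 4 (0.24 log units; within the scatter). Set beside the earlier case, the same change reads alike on the two cores, with no difference that can be told from the scatter: the same change on two cores in this assay, a 1.0-fold lower number (0.02 log units; within the scatter) from compound 1 to compound 2 and a 1.7-fold higher number (0.24 log units; within the scatter) from compound 3 to compound 4, 1.8-fold (0.26 log units) apart, within the scatter of two such steps. Going by these compounds alone, this supports carrying the change between these two cores with little expected movement, but it rests on only two pairs and does not show that the same holds on any other core, nor why the number stays so close.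

The compounds shown leave open what a larger group, such as a longer chain, an amine or a carboxylic acid, would do in place of this methyl on that saturated chain carbon.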